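The source may report more compounds than this note shows. Statements on the series, on what has been measured and on what is new or still open speak of the compounds shown alone.

Measured so far:
compound 1 `CC(C)n1cnc2c(Nc3ccccc3)nc(NCOCc3ccc(C(=O)Nc4ccccc4N)cc3)nc21` — 6.58%
compound 2 `CCC(C)n1cnc2c(NCc3ccc(C(=O)Nc4ccccc4N)cc3)nc(Cl)nc21` — 45%

In a functional assay on HepG2 cells (Homo sapiens) for antiproliferative activity, read by CCK-8 assay, with a stated time of 72 h, tested at 2 uM (a higher number here means a stronger effect of the compound at the concentration tested, a lower number a weaker effect), compound 1 gives the lowest of the two numbers. Going by the values given here, compound 2 sits higher, a gap that is beyond the usual scatter; the two structures differ in more than one place, so no single step is drawn between them, and their two values show only that compound 2 is the stronger of the pair at the tested concentration.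

The next compound, compound 3 `CC(C)n1cnc2c(Nc3ccccc3)nc(NCOCc3ccc(/C=C/C(=O)Nc4ccccc4N)cc3)nc21`, is not yet measured. It differs from compound 1 in one place: 2-((2-aminophenyl)carbamoyl)ethenyl in place of (2-aminophenyl)carbamoyl on an aromatic carbon. The shared core of compound 1 is kept. Among the compounds with values here, no step between measured compounds bears on this change, so the expectation rests on the low starting value of compound 1 alone.

In this assay the expected step of a number 8.4 percentage points higher from compound 1 to compound 3 (within the scatter) is upward but small, quite possibly not beyond the scatter. Compound 3 is estimated at 15%, within a range from 0% to 40%.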

Compound 3, a percentage reported as inhibition, at one concentration (the size of the read-out at that concentration, not a potency): 1.46%
Compound 3: the middle estimate sits 13.5 percentage points above what was measured; measured number inside the range.
By their numbers in this assay, from the lowest: compounds 3 and 1 (each within the scatter of the next); then compound 2.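

In this assay, 2-((2-aminophenyl)carbamoyl)ethenyl in place of (2-aminophenyl)carbamoyl on an aromatic carbon, para to a large group, gives a number 5.1 percentage points lower from compound 1 to compound 3 (within the scatter), so this first single-place comparison in the series separates the two groups by no more than the scatter. The reading is limited: compound 1 already starts at 6.58%, leaving little room for a downward step to show, and the added ethenyl is tested here only on this one low-valued compound. No supporting data on hand account for the result.

Open, going by these compounds, is whether a longer chain in place of the ethenyl, or a hydroxamic acid in place of the (2-aminophenyl)carbamoyl, would change the number at this position. Also open, on these data alone, is whether the ethenyl change gives a similar step on the shared core of compound 2, which starts higher.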